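Extending the hydroxamate chain on compound 2

The source may hold more compounds than are shown below. What is called first, only, known or untested is meant among the compounds shown, and "the series" means these compounds.

Compound 2 `Nc1ncnc2c1c(-c1cnc3[nH]ccc3c1)nn2CCCC(=O)NO` stands only at a limit: in a functional assay on HepG2 cells (Homo sapiens) for inhibition, read by MTT assay, with a stated time of 72 h (a lower number here means a stronger inhibitor, a higher number a weaker inhibitor), compound 2 gives > 50000 nM, which is a limit of the assay and not a number. Compound 4 `Nc1ncnc2c1c(-c1cnc3[nH]ccc3c1)nn2CCCCCCC(=O)NO` differs from it by 3-(hydroxycarbamoyl)propyl in place of hydroxycarbamoyl on a saturated chain carbon, three bonds along the chain from an aromatic nitrogen. Among the measured compounds, compound 1 `CNC(=O)CCCCCCCn1nc(-c2ccc3oc(N)nc3c2)c2c(N)ncnc21` gives 3640 nM in this assay, and compound 3 `Nc1nc2cc(-c3nn(CCCCCCCCCC(=O)NO)c4ncnc(N)c34)ccc2o1` gives 28600 nM; the step of a 7.9-fold higher number from compound 1 to compound 3 (0.90 log units; beyond the scatter) alters the terminal group of the chain on a different core, so no measured step bears directly on lengthening the chain in compound 4. Since compound 3 with its long hydroxycarbamoyl chain reaches a number, compound 4 is expected to do so as well, at 20000 nM, between 5000 nM and 60000 nM. The expected step is an at least 2.5-fold lower number from compound 2 to compound 4 (0.39 log units; beyond the scatter).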

Compound 4, half-maximal inhibitory concentration: 10300 nM
For compound 4 the middle estimate is 1.9-fold (0.29 log units) above the measured one; the range from low to high includes it.
By their numbers in this assay, from the lowest: compound 1; then compound 4; then compound 3. At a limit, above all of these: compound 2.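

Compound 2 stands at a limit and not a number: the limit of > 50000 nM in this assay, at which 1 of the 4 values shown sits. In this assay, 3-(hydroxycarbamoyl)propyl in place of hydroxycarbamoyl at this place gives an at least 4.8-fold lower number from compound 2 to compound 4 (0.68 log units; beyond the scatter). Going by these compounds alone, this is the first measured sign that lengthening the hydroxamate chain on this shared core lowers the number, though with only one end of the step measured, its true size stays unknown.

The compounds shown leave open whether a longer chain on this core would lower the number further. They also leave open whether a carboxylic acid or a methylcarbamoyl group at the chain end would keep the effect.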